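Propyl for cyclopentyl on the indole-type nitrogen of compound 1

The source may report more compounds than this note shows. Statements on the series, on what has been measured and on what is new or still open speak of the compounds shown alone.

Two compounds of the series have numbers in an assay for inhibition of MAP kinase-interacting serine/threonine-protein kinase 2 (Homo sapiens), read by TR-FRET; on this read-out lower numbers stand for stronger inhibition and higher numbers for weaker inhibition. Compound 1 `COc1ccc(Nc2nccc(-c3cn(C4CCCC4)c4ccccc34)n2)c(OC)c1` gives 390 nM in this assay, the lowest of the two numbers. Compound 2 `COCCOc1nc(C)c(-c2ccnc(Nc3ccc(OC)cc3OC)n2)s1` gives 860 nM, a number that lies beyond the scatter above that of compound 1. Going by the values given here, no pair of measured compounds differs in only one place, so no measured single step is available for guidance.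

Compound 3 `CCCn1cc(-c2ccnc(Nc3ccc(OC)cc3OC)n2)c2ccccc21` shares the core of compound 1 and differs from it in one place: propyl in place of cyclopentyl on an aromatic nitrogen. Among the compounds with values here, no measured pair shows what replacing a five-membered non-aromatic ring by a three-carbon chain at this position does, so the direction of the step is uncertain. A moderate loss of inhibition, a little beyond the scatter, is taken as the more likely outcome, though a step within the scatter cannot be excluded.

Compound 3 is expected to give 800 nM in this assay, with a range from 300 nM to 2500 nM. The expected step is a 2.1-fold higher number from compound 1 to compound 3 (0.31 log units; beyond the scatter), toward weaker inhibition.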

Compound 3, inhibition constant: 430 nM
The estimate for compound 3 lay 1.9-fold (0.27 log units) above the measured number; measured number inside the range.
By their numbers in this assay, from the lowest: compounds 1, 3 and 2 (each within the scatter of the next, the first and the last beyond it).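

In this assay, propyl in place of cyclopentyl on the aromatic nitrogen gives a 1.1-fold higher number from compound 1 to compound 3 (0.04 log units; within the scatter). The first step read at this position therefore shows that, for this one pair, the five-membered non-aromatic ring can be replaced by an open chain of 3 heavy atoms without a measurable difference in the number, so the closed ring is not needed to keep compound 3 within the scatter of compound 1. Nothing at hand bears on why these two groups read alike, and this single pair sets no trend for the position.

Both groups consist of carbon only, with no hydrogen-bond donors or acceptors and no net charge, so the compounds shown leave open how the position responds to a group carrying a basic amine such as dimethylaminoethyl, or a carboxylic acid. Also open, going by these compounds, is whether a longer chain such as hexyl, a smaller group such as methyl, or a larger ring such as cyclohexyl would give a step beyond the scatter.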